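This account rests on a few compounds, and the source may have more. Where it says the series, first, only, none or still open, it means among the compounds named here.

Three analogues on a shared core have been run in a functional assay on ECa-109 cells for inhibition, with ECa-109 cell line (Homo sapiens) as the target, read by sulforhodamine B assay; on this read-out lower numbers stand for stronger inhibition and higher numbers for weaker inhibition. Compound 1, `COc1cccc(NC2=CC(=O)c3c(nc4n3[C@H]3OC[C@@H](O)[C@H]3OC4)C2=O)c1`, gives 3340 nM in this assay. Compound 2, `O=C1C(Nc2cccc(Cl)c2)=CC(=O)c2c1nc1n2[C@H]2OC[C@@H](O)[C@H]2OC1`, gives 3080 nM. Compound 3, `COc1ccc(NC2=CC(=O)c3c(nc4n3[C@H]3OC[C@@H](O)[C@H]3OC4)C2=O)cc1`, gives 3410 nM. On these numbers compound 3 carries the highest value, yet each of its neighbours lies within the scatter: the step of a 1.0-fold higher number from compound 1 to compound 3 (0.01 log units; within the scatter) and the step of a 1.1-fold higher number from compound 2 to compound 3 (0.04 log units; within the scatter) are both too small to count as a change, as is the step of a 1.1-fold lower number from compound 1 to compound 2 (0.04 log units; within the scatter) between the two remaining compounds. Exchanging the aryl substituent among methoxy and chloro, or moving it between the two positions tried, has left this assay flat across the set.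

Compound 4, `CCOc1ccc(NC2=CC(=O)c3c(nc4n3[C@H]3OC[C@@H](O)[C@H]3OC4)C2=O)cc1`, is the next member. Relative to compound 3 the change is methyl in place of hydrogen on a saturated chain carbon bound to an oxygen on an aromatic ring. Among the measured compounds shown here, no measured step addresses a chain extension at this ether; the only steps in hand concern the aryl substituent itself, and all three are within the scatter. The working expectation is therefore that this assay stays flat: the step of a 1.0-fold lower number from compound 3 to compound 4 (0.00 log units; within the scatter) is estimated to be no larger than the scatter, in either direction. Compound 4 is expected to give about 3400 nM, within a range of 1700 nM to 6800 nM.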

Compound 4, half-maximal inhibitory concentration: > 4000 nM
Compound 4 was reported as a limit; the forecaster's own chance of this, stated with the estimate: 5%; at least 1.1-fold (0.07 log units) between middle value and limit.
By their numbers in this assay, from the lowest: compounds 2, 1 and 3 (each within the scatter of the next). At a limit, above all of these: compound 4.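

Compound 4 is reported only as a limit, not as a number: the limit of > 4000 nM in this assay, at which 1 of the 4 values shown sits. Among the compounds shown here, the first step at the ether chain itself, methoxy to ethoxy on the 4-methoxyphenyl group, reads an at least 1.1-fold higher number from compound 3 to compound 4 (0.06 log units; that floor lies within the scatter), so one added methyl on this saturated chain carbon gives no established change, yet the open-ended reading means a larger shift is not excluded either. For the compounds shown here, the comparisons with the other two aryl groups, an at least 1.2-fold higher number from compound 2 to compound 4 (0.11 log units; that floor lies within the scatter) and an at least 1.1-fold higher number from compound 1 to compound 4 (0.07 log units; that floor lies within the scatter), are floors of the same kind, so the flat picture from the earlier compounds is neither confirmed nor broken, and the 4-ethoxyphenyl group is the first whose value is not pinned from both sides.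

How far the true value of compound 4 lies past its limit stays unresolved, and with it whether the ethoxy group matters at all in this read-out. Also open, as far as these compounds go, is whether a longer chain on this oxygen, such as propoxy or butoxy, or a free hydroxyl or an amine in place of the ether, would move the value beyond the scatter.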